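Adding a Fluoro Group: Expected Cytotoxicity of Compound 4

The source may hold more compounds than are shown below. What is called first, only, known or untested is meant among the compounds shown, and "the series" means these compounds.

Three compounds have been measured in a functional assay on HeLa cells (Homo sapiens) for cytotoxicity, read by MTT assay, with a stated time of 72 h; on this read-out lower numbers stand for stronger inhibition and higher numbers for weaker inhibition:

Compound 1 `N/C(=N\NC(=S)N1CCCC1)c1ccc(F)cn1` gives 1800 nM.
Compound 2 `Cc1ccnc(/C(N)=N/NC(=S)N2CCSCC2)c1` gives 15500 nM.
Compound 3 `N/C(=N\NC(=S)N1CCSCC1)c1ccccn1` gives 7800 nM.

Compound 3 stands second highest of the three numbers. Its nearest neighbour is compound 2, whose number is higher but within the scatter; the step of a 2.0-fold lower number from compound 2 to compound 3 (0.30 log units; within the scatter) is hydrogen in place of methyl on an aromatic carbon. Compound 1 lies furthest away, with a lower number beyond the scatter, but compound 1 differs from compound 3 in two places, so its value alone says nothing about the fluoro group.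

Compound 4 `N/C(=N\NC(=S)N1CCSCC1)c1ccc(F)cn1` is to be measured in this assay. The change is fluoro in place of hydrogen on an aromatic carbon, placed two atoms from the ring nitrogen, para to a large group. For the measured compounds named here, no measured step adds a fluoro group on its own, so the only guide is the small size of the one step that was measured. A step of similar size or none beyond the scatter is expected; the expected step is a 1.7-fold lower number from compound 3 to compound 4 (0.24 log units; within the scatter). Compound 4 is expected to give about 4500 nM, within a range from 1500 nM to 13000 nM.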

Compound 4, half-maximal inhibitory concentration: 1700 nM
Compound 4: middle estimate off by 2.6-fold (0.42 log units), on the high side, within the range that was stated.
By their numbers in this assay, from the lowest: compounds 4 and 1 (each within the scatter of the next); then compounds 3 and 2 (each within the scatter of the next).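

In this assay, for the compounds shown here, fluoro in place of hydrogen on an aromatic carbon, two atoms from the ring nitrogen and para to a large group, gives a 4.6-fold lower number from compound 3 to compound 4 (0.66 log units; beyond the scatter), the first single change in this set that goes beyond the scatter, so this position does respond to substitution. With the fluoro group present, thiomorpholin-4-yl in place of pyrrolidin-1-yl on the thiocarbonyl carbon gives a 1.1-fold lower number from compound 1 to compound 4 (0.02 log units; within the scatter), so this pair shows no difference that can be told from the scatter. Nothing measured here bears on the reason for the fluoro step.

Open, as far as these compounds go, is whether a chlorine atom, a methoxy group or an amine at this same place would lower the number as well. Also open, from the compounds shown here alone, is whether the fluoro step would keep its size with pyrrolidin-1-yl on the thiocarbonyl carbon.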